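A few compounds are considered here, and "the series" means these few. Any claim that something is new, unique, unknown or untested is made for them only; others in the source may bear on it.

In an ADME assay on MRC5 cells (Homo sapiens) for cytotoxicity, read by neutral red uptake, with a stated time of 24 h (on this read-out lower numbers stand for stronger inhibition and higher numbers for weaker inhibition), compound 1 (`CC(C)c1cc2c3c(c1OC(=O)CCl)OC(=O)[C@@]31CCCC(C)(C)[C@@H]1CC2`) gives 130000 nM and compound 2 (`CCC(=O)Oc1c(C(C)C)cc2c3c1OC(=O)[C@@]31CCCC(C)(C)[C@@H]1CC2`) gives 125000 nM, so the two stand level on the shared core. Within the data shown here, the only measured step, a 1.0-fold lower number from compound 1 to compound 2 (0.02 log units; within the scatter), is methyl in place of chloro on a saturated chain carbon bound to a carbonyl carbon, and it stays within the scatter.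

Compound 3 (`CC(C)c1cc2c3c(c1OC(=O)CCCc1c[nH]c4ccccc14)OC(=O)[C@@]31CCCC(C)(C)[C@@H]1CC2`) departs from compound 2 by a much larger change: (1H-indol-3-yl)methyl in place of hydrogen on a saturated chain carbon, two bonds along the chain from a carbonyl carbon. In words, this is (1H-indol-3-yl)methyl in place of hydrogen on a saturated chain carbon, two bonds along the chain from a carbonyl carbon. The same difference reads ethyl to 3-(1H-indol-3-yl)propyl.

Among the measured compounds shown here, the one measured step bears on this only weakly, since it concerns a different exchange on the chain and no measured compound carries an added group of this kind. A modest move towards stronger inhibition in this assay is expected, though tentatively, and a result within the scatter would not be surprising. The expected step is a 1.6-fold lower number from compound 2 to compound 3 (0.19 log units; within the scatter). For compound 3 the estimated value is 80000 nM, with an expected range of 30000 nM to 180000 nM.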

Compound 3, half-maximal inhibitory concentration: 54500 nM
Beside the measured number, compound 3's estimate is 1.5-fold (0.17 log units) above it; the measured number falls inside the stated range.
By their numbers in this assay, from the lowest: compound 3; then compounds 2 and 1 (each within the scatter of the next).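

In this assay, among these compounds, this position on the chain is the first place where a change gives a step beyond the scatter: a 2.3-fold lower number from compound 2 to compound 3 (0.36 log units; beyond the scatter), whereas the exchange of chloro for methyl stayed within it. The outcome does not depend on which short-chain compound serves as the reference, since a 2.4-fold lower number from compound 1 to compound 3 (0.38 log units; beyond the scatter) is also beyond the scatter and of modest size. A large group therefore moves the number only modestly here, and nothing available accounts for that shift.

The compounds shown do not separate the contribution of the indole rings from that of the longer chain, so a plain hexyl chain or a phenyl group in place of the (1H-indol-3-yl)methyl would be needed to tell the two apart. Also open, from the compounds shown here alone, is how an amine or a carboxylic acid at this saturated chain carbon, two bonds along the chain from a carbonyl carbon, would compare, and whether the direction of the step would hold for such groups.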